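Swapping the benzothiazole of compound 1 for an aminobenzimidazole

The source may report more compounds than this note shows. Statements on the series, on what has been measured and on what is new or still open speak of the compounds shown alone.

Compound 1 `CCn1cc(-c2nc3ccccc3s2)c(=O)c2cc(F)c(N3CCNCC3)cc21` gives 11300 nM in a functional assay on A2780 cells (Homo sapiens) for cytotoxicity, read by MTT assay, with a stated time of 48 h (a lower number here means a stronger inhibitor, a higher number a weaker inhibitor), the highest of the two numbers shown; compound 2 `CCn1cc(-c2nc3ccc([N+](=O)[O-])cc3s2)c(=O)c2cc(F)c(N3CCNCC3)cc21` gives 700 nM, and the change a 16-fold lower number from compound 1 to compound 2 (1.21 log units; beyond the scatter) is a nitro in place of hydrogen on an aromatic carbon. Compound 3 `CCn1cc(-c2nc3ccc(N)cc3[nH]2)c(=O)c2cc(F)c(N3CCNCC3)cc21` differs from compound 1 by a group of 10 heavy atoms (7 carbon, 3 nitrogen; one five-membered aromatic ring with 2 hetero atoms, one six-membered aromatic ring of carbon only) in place of a group of 9 heavy atoms (7 carbon, 1 nitrogen, 1 sulfur; one five-membered aromatic ring with 2 hetero atoms, one six-membered aromatic ring of carbon only), on an aromatic carbon. Among the compounds with values here, no measured step touches this exchange of the whole fused group, so the one large step from compound 1 to compound 2 offers only loose guidance. The expected step is a 2.3-fold lower number from compound 1 to compound 3 (0.35 log units; beyond the scatter), giving an estimate for compound 3 of 5000 nM within a range of 1000 nM to 30000 nM.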

Compound 3, half-maximal inhibitory concentration: 51500 nM
Compound 3: middle estimate off by 10-fold (1.01 log units), on the low side; the measured number lies above the stated range.
By their numbers in this assay, from the lowest: compound 2; then compound 1; then compound 3.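

Exchanging the 1,3-benzothiazol-2-yl group for the entering fused group gives a 4.6-fold higher number from compound 1 to compound 3 (0.66 log units; beyond the scatter) in this assay and so moves the number upward at this aromatic carbon, whereas the earlier step gave a 16-fold lower number from compound 1 to compound 2 (1.21 log units; beyond the scatter) on the same group. This exchange joins two differences, nitrogen in place of the ring sulfur and an added amine, which this step cannot separate. Nothing at hand explains the rise. As far as these compounds go, it remains open how the 1,3-benzothiazol-2-yl group alone would respond to an amine, or to a chlorine or a carboxylic acid, in place of that aromatic hydrogen. From the compounds shown here alone, the fused group of compound 3 without its amine also remains open.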